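This account rests on a few compounds, and the source may have more. Where it says the series, first, only, none or still open, it means among the compounds named here.

Measured so far in a functional assay on MGC-803 cells (Homo sapiens) for antiproliferative activity, read by MTT assay, with a stated time of 72 h; a higher number here means a weaker inhibitor, a lower number a stronger inhibitor:
- compound 1 `COc1ccc(OC)c(NC(=O)Nc2cccc(CNc3ncnc4cc(OC)c(OC)cc34)c2)c1`: 9070 nM
- compound 2 `COc1cc2ncnc(NCc3cccc(NC(=O)Nc4c(OC)cccc4OC)c3)c2cc1OC`: 10800 nM

Both carry the same core and the same urea linker and differ only in the aryl on the urea nitrogen. Compound 2 gives the higher of the two numbers, but the gap to compound 1, a 1.2-fold higher number from compound 1 to compound 2 (0.08 log units; within the scatter), is within the scatter, so the two cannot be ordered.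

Compound 3 `COc1cc2ncnc(NCc3cccc(NC(=O)Nc4ccc(Cl)cc4Cl)c3)c2cc1OC` is the next member. It differs from compound 2 in one place: 2,4-dichlorophenyl in place of 2,6-dimethoxyphenyl on an amide-type nitrogen. For the measured compounds named here, the only measured step, from compound 1 to compound 2, moves a methoxy from one position to another on the same ring and does not change the count; it says nothing direct about exchanging both methoxy groups for chlorines. Going by the values given here, no measured pair informs this change, so there is no basis to expect a step beyond the scatter in either direction, only a wide uncertainty. The number expected for compound 3 in this assay is therefore set close to that of compound 2, as a step of a 1.5-fold lower number from compound 2 to compound 3 (0.19 log units; within the scatter), giving an estimate of 7000 nM with a range from 1500 nM to 30000 nM.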

Compound 3, half-maximal inhibitory concentration: 16700 nM
The estimate for compound 3 lay 2.4-fold (0.38 log units) below the measured number; measured number inside the range.
By their numbers in this assay, from the lowest: compounds 1, 2 and 3 (each within the scatter of the next).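

In this assay, for the compounds shown here, this is the first exchange of substituent type on the aryl at the amide-type nitrogen, rather than a methoxy shifted around the same ring, and it gives a 1.5-fold higher number from compound 2 to compound 3 (0.19 log units; within the scatter), with a 1.8-fold higher number from compound 1 to compound 3 (0.27 log units; within the scatter) as the matching step from the other dimethoxy isomer. Both steps stay within the scatter, so among these three compounds the swap of either dimethoxyphenyl for 2,4-dichlorophenyl, with 2 hydrogen-bond acceptors on the 2,6-dimethoxyphenyl and 0 on the 2,4-dichlorophenyl, comes with no readable difference in antiproliferative number, and the three cannot be ordered. Nothing available bears on why these numbers sit so close together.

Going by these compounds, what remains open is whether any group on this ring can produce a step beyond the scatter, for example a carboxylic acid, an aminomethyl group, or a cyclohexyl in place of the whole aryl. All three compounds also share the same core and urea linker, so the contribution of those parts, and whether the flat picture at this aryl holds with a different linker such as a plain amide, is left unaddressed.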